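Halogenated aryl swap from compound 2 toward compound 4

The source may report more compounds than this note shows. Statements on the series, on what has been measured and on what is new or still open speak of the compounds shown alone.

Three measured compounds share one core and differ in the halogenated aryl group and in the linker carrying it. In a functional assay on PC-3 cells (Homo sapiens) for antiproliferative activity, read by MTT assay, tested at 1 uM (a higher number here means a stronger effect of the compound at the concentration tested, a lower number a weaker effect), compound 1 `COc1cc(C2=NN(C(C)=O)C(c3cccc(F)c3)O2)cc(OC)c1OC` gives 16.5%, compound 3 `COc1cc(C2=NN(C(C)=O)C(c3c(Cl)cccc3Cl)O2)cc(OC)c1OC` gives 5.1%, and compound 2 `COc1cc(C(=O)N/N=C/c2ccc(F)c(F)c2)cc(OC)c1OC` gives 35.1%, the highest of the three, with compound 1 below it beyond the scatter and compound 3 further still. Going by the values given here, the one single-point step measured in the set is a number 11.4 percentage points lower from compound 1 to compound 3 (beyond the scatter). Compound 4 `COc1cc(C(=O)N/N=C/c2c(Cl)cccc2Cl)cc(OC)c1OC` is not yet measured; it differs from compound 2 by 2,6-dichlorophenyl in place of 3,4-difluorophenyl on a carbon with a double bond to nitrogen. The step from compound 1 to compound 3 bears on this change, although there the aryl sits on a saturated ring carbon and the departing group is a different fluorophenyl. A fall of comparable size is expected, giving a number 12.1 percentage points lower from compound 2 to compound 4 (beyond the scatter). Compound 4 is therefore estimated at 23%, within 10% to 36%.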

Compound 4, a percentage reported as inhibition, at one concentration (the size of the read-out at that concentration, not a potency): 43%
The estimate for compound 4 lay 20 percentage points below the measured number; measured number outside the range, above it.
By their numbers in this assay, from the lowest: compound 3; then compound 1; then compounds 2 and 4 (each within the scatter of the next).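

In this assay, 2,6-dichlorophenyl in place of 3,4-difluorophenyl on a carbon with a double bond to nitrogen gives a number 7.9 percentage points higher from compound 2 to compound 4 (within the scatter), so this position accepts the change without a readable shift. The fall seen on the saturated ring carbon, a number 11.4 percentage points lower from compound 1 to compound 3 (beyond the scatter), does not carry over here, although the group leaving there is a different fluorophenyl. Nothing available explains why the two settings differ.

Open, as far as these compounds go, is whether an aryl group carrying a dimethylamino group or a carboxylic acid would hold the read-out at this carbon.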